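Rho kinase series: three limits, one compound outstanding

A few compounds are considered here, and "the series" means these few. Any claim that something is new, unique, unknown or untested is made for them only; others in the source may bear on it.

Compound 1 `Cc1cc(NC(=O)COc2ccc3c(=O)ccoc3c2)cc(NC(=O)c2ccc(N(C)C)cc2)c1`: in an assay on isolated protein for inhibition of Rho-associated protein kinase 1 (Homo sapiens), read by scintillation counting, radiometric assay and 33P incorporation, with a stated time of 40 min, in the presence of a further agent that is not named here (on this read-out higher numbers stand for weaker inhibition and lower numbers for stronger inhibition), compound 1 gives > 10000 nM, a limit of the assay and not a number.
Compound 2 `CN(C)c1ccc(C(=O)Nc2cc(NC(=O)COc3ccc4c(=O)ccoc4c3)cc(C(F)(F)F)c2)cc1`: in this assay compound 2 gives > 10000 nM, again a limit.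
Compound 3 `Cc1cc(NC(=O)COc2ccc3c(=O)ccoc3c2)ccc1NC(=O)c1ccc(N(C)C)cc1`: in this assay compound 3 gives > 10000 nM, also a limit.

Compounds 1 and 2 share one core; compound 3 and the unmeasured compound 4 `CN(C)c1ccc(C(=O)Nc2ccc(NC(=O)COc3ccc4c(=O)ccoc4c3)cc2C(F)(F)F)cc1` share another. The difference between the two cores is not broken down here. From compound 1 to compound 2 the change is trifluoromethyl in place of methyl on an aromatic carbon. The resulting step that the two limits leave unreadable from compound 1 to compound 2 cannot be read, because of the limit of > 10000 nM in this assay, at which 3 of the 3 values shown sit. From compound 3 to compound 4 the change is trifluoromethyl in place of methyl on an aromatic carbon, the same kind of change but not at the same place: in compound 2 the trifluoromethyl is meta to two large groups, whereas in compound 4 it is ortho to a large group and meta to a large group. No pattern can be claimed from three limits.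

For compound 4 the expected step that the limit leaves unreadable from compound 3 to compound 4 rests on a step that the two limits leave unreadable from compound 1 to compound 2, which gives no readable size. Compound 4 is therefore expected at 15000 nM, most likely reported as a limit again, with an estimated range of 4000 nM to 60000 nM.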

Compound 4, half-maximal inhibitory concentration: > 10000 nM
Compound 4: a limit, no number; the forecaster's own chance of this, stated with the estimate: 85%; the middle value lies beyond the limit too.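

The step from compound 3 to compound 4 in this assay cannot be read, because both compounds give a limit of the assay and not a number: the limit of > 10000 nM in this assay, at which 4 of the 4 values shown sit.

The compounds shown leave open whether trifluoromethyl in place of methyl changes inhibition at all, and which structural change, if any, would give a measurable value in this assay.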